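A few compounds are considered here, and "the series" means these few. Any claim that something is new, unique, unknown or untested is made for them only; others in the source may bear on it.

Compound 2 `COc1ccc(-c2nc(C)c(C(=O)CSc3nc(N)c(C#N)c(-c4ccc(OC)cc4)n3)s2)cc1` is the lower of the two measured compounds in a functional assay on U-87MG ATCC cells for antiproliferative activity against U-87 MG (Homo sapiens), read by MTT assay, with a stated time of 48 h, tested at 100 uM; on this read-out higher numbers stand for a weaker effect at the one concentration tested and lower numbers for a stronger effect: compound 2 gives 0.26%, while compound 1 `COc1ccc(-c2nc(SCC(=O)c3sc(-c4ccccc4)nc3C)nc(N)c2C#N)cc1` gives 17.2%. Among the compounds with values here, the one measured step, a number 16.9 percentage points lower from compound 1 to compound 2 (beyond the scatter), came from a methoxy in place of hydrogen on an aromatic carbon.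

Compound 3 `COc1ccc(-c2nc(C)c(C(=O)CSc3nc(N)c(C#N)c(-c4ccc(Cl)cc4)n3)s2)cc1` differs from compound 2 in a different place: chloro in place of methoxy on an aromatic carbon, on an aromatic carbon of a six-membered aromatic ring of carbon only, para to a large group. Within the data shown here, no measured step matches this exchange, so the only guidance is indirect. The step from compound 1 to compound 2 shows that a single group swap on an aromatic ring can move this read-out beyond the scatter, and since compound 2 already sits near the bottom of the scale, any movement for compound 3 can only be upward or none.

Compound 3 is therefore expected to remain a strong compound in this assay, with a step of about a number 7.7 percentage points higher from compound 2 to compound 3 (within the scatter) judged as likely but uncertain. The estimate for compound 3 is 8%, with a range from 0% to 30%.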

Compound 3, a percentage reported as activity, at one concentration (the size of the read-out at that concentration, not a potency): 3.9%
Beside the measured number, compound 3's estimate is 4.1 percentage points above it; low and high end bracket the measured number.
By their numbers in this assay, from the lowest: compounds 2 and 3 (each within the scatter of the next); then compound 1.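

In this assay, replacing the 4-methoxyphenyl with a 4-chlorophenyl gives a number 3.6 percentage points higher from compound 2 to compound 3 (within the scatter), so compound 2 and compound 3 cannot be told apart on this read-out. This shows that the position para to a large group on this aromatic ring accepts chloro, a single chlorine atom with no hydrogen-bond acceptor, in place of methoxy, with its carbon and oxygen, without a change that can be distinguished from scatter, whereas the earlier methoxy step at another place, a number 16.9 percentage points lower from compound 1 to compound 2 (beyond the scatter), lay beyond it. No measurement at hand offers an explanation for this result.

Both compounds sit close to the bottom of the scale at the one concentration tested, so a real difference in potency between them could remain hidden, and a full concentration series would be needed to reveal one. Going by these compounds, it also remains open whether this position would tolerate a very different group, such as an amine or a carboxylic acid, as readily as it accepts chloro and methoxy.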